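The source may hold more compounds than are shown below. What is called first, only, known or untested is meant among the compounds shown, and "the series" means these compounds.

Two compounds share a common core and differ only in the group on a nitrogen on an aromatic ring. Compound 1 `C=CC(=O)Nc1cccc(NC(=O)CSc2nc(Nc3ccccc3F)c3ccccc3n2)c1` carries a 2-fluorophenyl there, and in a functional assay on PC-3 cells (Homo sapiens) for inhibition, read by MTT assay, with a stated time of 72 h (a higher number here means a weaker inhibitor, a lower number a stronger inhibitor), compound 1 gives 9340 nM. Compound 2 `C=CC(=O)Nc1cccc(NC(=O)CSc2nc(Nc3cccc(Br)c3)c3ccccc3n2)c1` carries a 3-bromophenyl there, and in this assay compound 2 gives 15000 nM. The step of a 1.6-fold higher number from compound 1 to compound 2 (0.21 log units; within the scatter) leaves the two numbers within the scatter of each other, so compound 2 stands at a number that cannot be told apart from that of compound 1.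

Compound 3 `C=CC(=O)Nc1cccc(NC(=O)CSc2nc(Nc3ccc(F)cc3)c3ccccc3n2)c1` has not yet been measured; it differs from compound 2 by 4-fluorophenyl in place of 3-bromophenyl on a nitrogen on an aromatic ring. For the measured compounds named here, the only measured step that bears on this change, a 1.6-fold higher number from compound 1 to compound 2 (0.21 log units; within the scatter), also swapped one halogenated phenyl for another and stayed within the scatter. Compound 3 is therefore expected to sit close to compound 2 in this assay, with an expected step of a 1.3-fold lower number from compound 2 to compound 3 (0.10 log units; within the scatter). For compound 3 the estimate is 12000 nM, ranging from 4500 nM to 32000 nM.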

Compound 3, half-maximal inhibitory concentration: 8240 nM
Compound 3: the middle estimate sits 1.5-fold (0.16 log units) above what was measured; the range from low to high includes it.
By their numbers in this assay, from the lowest: compounds 3, 1 and 2 (each within the scatter of the next).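

In this assay the change to 4-fluorophenyl on a nitrogen on an aromatic ring gives a 1.8-fold lower number from compound 2 to compound 3 (0.26 log units; within the scatter) and also a 1.1-fold lower number from compound 1 to compound 3 (0.05 log units; within the scatter) so all three halogenated phenyl groups now lie within the scatter of one another. The result adds a direct comparison of 2-fluorophenyl with 4-fluorophenyl, and it shows no difference between these two groups that can be told from the scatter. No measurement here offers an explanation for this result.

On these data alone, all three groups are phenyl rings carrying a single halogen, so the effect of an unsubstituted phenyl, a methoxyphenyl, a cyclohexyl or a phenyl bearing a carboxylic acid at this place remains open. As far as these compounds go, whether any such group would move the number beyond the scatter also remains open.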